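From pyrrolidin-1-yl to piperidin-1-yl on the side chain

The compounds below may be only part of what the source reports. "The series", "measured", "known", "first", "only" and "open" are said of these compounds alone.

Values measured in an ADME assay on HOS cells (Homo sapiens) for cytotoxicity (a higher number here means that more compound is tolerated, a lower number that less compound is tolerated), follow
- compound 1 `CN(Cc1nc2cccc(CN)c2[nH]1)C1CCCc2cccnc21` reads > 20000 nM and this is a limit of the assay
- compound 2 `CN(Cc1nc2cccc(CCCN3CCCC3)c2[nH]1)C1CCCc2cccnc21` reads 8200 nM and this is a true number

Within the data shown here, compound 2 holds the only true number in this assay so far, which leaves it without a measured rank. Compound 1 offers only a limit.

The next compound is compound 3 `CN(Cc1nc2cccc(CCCN3CCCCC3)c2[nH]1)C1CCCc2cccnc21` which carries piperidin-1-yl in place of pyrrolidin-1-yl on a saturated chain carbon, three bonds along the chain from an aromatic carbon. Otherwise it matches compound 2.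

Among the measured compounds shown here, one measured step bears on this change, and only loosely: an at least 2.4-fold lower number from compound 1 to compound 2 (0.38 log units; beyond the scatter). That step replaced amino with 2-(pyrrolidin-1-yl)ethyl, a far larger change than going from a five-membered to a six-membered ring. For the measured compounds named here, no measured step covers the ring change itself, so no step beyond the scatter is expected.

The expected change is small (a 1.1-fold lower number from compound 2 to compound 3 (0.04 log units; within the scatter)). This expectation is anchored on compound 2 (8200 nM).

Compound 3 is estimated at 7500 nM with an expected range from 3800 nM to 15000 nM in this assay.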

Compound 3, half-maximal cytotoxic concentration: 8700 nM
The estimate for compound 3 lay 1.2-fold (0.06 log units) below the measured number; low and high end bracket the measured number.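

In this assay, the change from pyrrolidin-1-yl to piperidin-1-yl on a saturated chain carbon, three bonds along the chain from an aromatic carbon, gives a 1.1-fold higher number from compound 2 to compound 3 (0.03 log units; within the scatter), so at this place the six-membered ring reads the same as the five-membered one within the usual scatter. The lower reading relative to the amino compound is therefore not confined to pyrrolidin-1-yl, since the piperidine-bearing chain also shows an at least 2.2-fold lower number from compound 1 to compound 3 (0.36 log units; beyond the scatter), a step of much the same kind as an at least 2.4-fold lower number from compound 1 to compound 2 (0.38 log units; beyond the scatter). Compound 1 reads > 20000 nM, which is a limit and not a number, and the steps from it are bounds only: the limit of > 20000 nM in this assay, at which 1 of the 3 values shown sits.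

The compounds shown leave open whether the tolerance in this assay holds when the ring at the end of the chain carries a second hetero atom, as in morpholine, or gives way to an open-chain amine such as dimethylamino. They also leave open how a longer or shorter chain would read with either of these two rings at its end.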